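Aryl Swap on the Fused Core, Stability Unknown

The source may report more compounds than this note shows. Statements on the series, on what has been measured and on what is new or still open speak of the compounds shown alone.

Compound 3 `Cc1nc(N2CCN(C)CC2)c2nc(-c3cccc(Cl)c3)n(C3CCOCC3)c2n1` stands lowest of the three compounds measured in an ADME assay (liver) for metabolic stability, with Liver microsome (Canis lupus familiaris) as the target, read by LC-MS, using microsomes, with a stated time of 30 min, tested at 4 uM; on this read-out lower numbers stand for a less stable compound and higher numbers for a more stable compound: compound 3 gives 45%, while compound 1 `Cc1nc(N2CCN(C)CC2)c2nc(-c3ccccc3Cl)n(CCO)c2n1` gives 99% and compound 2 `Cc1nc(N2CCN(C)CC2)c2nc(-c3ccccc3Cl)n(CCN3CCCC3=O)c2n1` gives 60%, and both of those gaps to compound 3 lie beyond the scatter. Compound 4 `COc1ccc(-c2nc3c(N4CCN(C)CC4)nc(C)nc3n2C2CCOCC2)c(C)c1` differs from compound 3 in a single place: 4-methoxy-2-methylphenyl in place of 3-chlorophenyl on an aromatic carbon. Within the data shown here, the only step measured so far, a number 39 percentage points lower from compound 1 to compound 2 (beyond the scatter), concerns the chain on the ring nitrogen and not the aryl group, so no measured step bears directly on the change from compound 3 to compound 4. With no guide to the direction, the expected step is no change at the digits printed from compound 3 to compound 4 (within the scatter), which is taken to lie within the scatter, and the range is kept wide to reflect that uncertainty. Compound 4 is therefore estimated to give 45% in this assay, with a range from 20% to 75%.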

Compound 4, percent of the compound remaining: 41%
Compound 4: middle estimate off by 4 percentage points, on the high side, and the stated range covers the measured number.
By their numbers in this assay, from the lowest: compounds 4 and 3 (each within the scatter of the next); then compound 2; then compound 1.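

In this assay, 4-methoxy-2-methylphenyl in place of 3-chlorophenyl on an aromatic carbon gives a number 4 percentage points lower from compound 3 to compound 4 (within the scatter), the first step read at this position of the shared core. With the oxan-4-yl group held constant, a group of 9 heavy atoms carrying oxygen and no chlorine thus leaves the two compounds within the scatter of each other, so this pair shows no sensitivity to the exchange. Nothing available explains this result.

The exchange alters the chlorine, the methyl and the methoxy together, so the share of each remains unresolved, and the two effects could also be cancelling each other. From the compounds shown here alone, whether a nitrile on the phenyl, or a pyridine ring in place of it, would give a number beyond the scatter remains open.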